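Trading a Fluoro for a Second Methyl

The source may report more compounds than this note shows. Statements on the series, on what has been measured and on what is new or still open speak of the compounds shown alone.

For the measured compounds named here, compound 2 `Cc1ccc(F)cc1COc1ccccc1C(=O)Nc1cccnc1` stands lowest of the two numbers measured so far in an assay on lysate for inhibition of phosphatidylcholine:ceramide cholinephosphotransferase 2 (Homo sapiens), read by HPLC, with stated times of 30 min and 2 h (a lower number here means a stronger inhibitor, a higher number a weaker inhibitor), where compound 2 gives 740 nM. Its nearest neighbour is compound 1 `Cc1ccccc1COc1ccccc1C(=O)Nc1cccnc1`, which in this assay gives 1500 nM; the step of a 2.0-fold lower number from compound 1 to compound 2 (0.31 log units; beyond the scatter) is a modest one. Compound 3 `Cc1cccc(C)c1COc1ccccc1C(=O)Nc1cccnc1` has not yet been measured. It differs from compound 2 in one place: 2,6-dimethylphenyl in place of 5-fluoro-2-methylphenyl on a saturated chain carbon bound to an oxygen on an aromatic ring. Going by the values given here, the only measured step that bears on this change is a 2.0-fold lower number from compound 1 to compound 2 (0.31 log units; beyond the scatter), which shows what the fluoro brought when it entered; compound 3 gives that fluoro up and gains a second methyl instead, and for the added methyl no step has been measured. The gain tied to the fluoro is therefore expected to be lost, while the second methyl remains an unknown, so a small move toward a higher number, or none beyond the scatter, is expected in this assay. Compound 3 is expected to give 1100 nM in this assay, with a range from 500 nM to 2500 nM, which would be a step of a 1.5-fold higher number from compound 2 to compound 3 (0.17 log units; within the scatter).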

Compound 3, half-maximal inhibitory concentration: 890 nM
For compound 3 the middle estimate is 1.2-fold (0.09 log units) above the measured one; the measured number falls inside the stated range.
By their numbers in this assay, from the lowest: compounds 2, 3 and 1 (each within the scatter of the next, the first and the last beyond it).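

In this assay the second methyl gives a 1.7-fold lower number from compound 1 to compound 3 (0.23 log units; within the scatter) and so cannot be told apart from the hydrogen it replaces, whereas the fluoro gave a 2.0-fold lower number from compound 1 to compound 2 (0.31 log units; beyond the scatter) and stood clear of the scatter. Exchanging 5-fluoro-2-methylphenyl for 2,6-dimethylphenyl on the saturated chain carbon gives a 1.2-fold higher number from compound 2 to compound 3 (0.08 log units; within the scatter) and these two groups cannot be told apart either, which leaves compound 3 within the scatter of both compound 1 and compound 2 even though those two lie beyond the scatter of each other. Nothing at hand accounts for this result.

The compounds shown leave open whether the second methyl has any real effect of its own in this series, and whether it and the fluoro would add up if both were carried by one ring. They also leave open what a chloro, a methoxy or a trifluoromethyl would do in place of the fluoro or of the second methyl.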